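The source may report more compounds than this note shows. Statements on the series, on what has been measured and on what is new or still open speak of the compounds shown alone.

Compound 2 `O=C1NCCN1c1ccc(S(=O)(=O)Nc2ccc(Cl)cc2)cc1` is the point of departure for the present step. For the measured compounds named here, in a functional assay on MCF7 cells (Homo sapiens) for antiproliferative activity, read by sulforhodamine B assay, with a stated time of 48 h (on this read-out higher numbers stand for weaker inhibition and lower numbers for stronger inhibition), compound 2 gives 170 nM, the only numerical value among the two measured compounds. Compound 1 `COc1ccc(NS(=O)(=O)c2ccc(N3CCNC3=O)cc2)cc1` differs from compound 2 by methoxy in place of chloro. In this assay compound 1 reaches only a limit of the assay, > 1000 nM. Going by the values given here, the single measured step therefore runs an at least 5.8-fold lower number from compound 1 to compound 2 (0.76 log units; beyond the scatter), anchored at the limit of > 1000 nM in this assay, at which 1 of the 2 values shown sits. Compound 3 `CCCCc1ccc(NS(=O)(=O)c2ccc(N3CCNC3=O)cc2)cc1` carries butyl in place of chloro on an aromatic carbon. Among the compounds with values here, no measured step involves butyl, and the exchange of methoxy for chloro does not speak to an exchange of chloro for butyl, so the expectation rests on compound 2 alone, with a broad range. For compound 3 the expected step is a 1.8-fold higher number from compound 2 to compound 3 (0.25 log units; within the scatter). Compound 3 is estimated in this assay at 300 nM, between 80 nM and 1500 nM.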

Compound 3, half-maximal inhibitory concentration: 770 nM
Compound 3: middle estimate off by 2.6-fold (0.41 log units), on the low side, and the stated range covers the measured number.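

Exchanging chloro for butyl on this aromatic carbon weakens inhibition in this assay, with a 4.5-fold higher number from compound 2 to compound 3 (0.66 log units; beyond the scatter), so a second replacement of chloro now falls short of compound 2, a result that the methoxy step alone could not give. Both compound 1 and compound 3 thus stand behind compound 2, and the larger group, with 4 heavy atoms in place of 1, still gives a measurable number. Butyl and methoxy, however, cannot be ranked against each other, as the comparison gives only an at least 1.2-fold lower number from compound 1 to compound 3 (0.11 log units; that floor lies within the scatter), a floor set by a limit of the assay: the limit of > 1000 nM in this assay, at which 1 of the 3 values shown sits.

Going by these compounds, how a shorter chain such as methyl or ethyl, or another halogen such as bromine or fluorine, would compare with chloro remains open. So does the effect of an amine or a carboxylic acid on this carbon.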